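The compounds below may be only part of what the source reports. "The series", "measured", "known", "first", "only" and "open" are said of these compounds alone.

Of the compounds shown here, three built on one shared core have been tested in an ADME assay on MT4 cells (Homo sapiens) for cytotoxicity, read by spectrophotometry, with a stated time of 5 days; on this read-out lower numbers stand for higher toxicity in this test and higher numbers for lower toxicity in this test. Compound 1 `CN(C)CN1C(=O)/C(=N\NC(=S)NO)c2cc(F)ccc21` carries a fluoro group on an aromatic carbon of the core; in this assay compound 1 gives 599000 nM. Compound 2 `CN(C)CN1C(=O)/C(=N\NC(=S)NO)c2cc(Cl)ccc21` differs from compound 1 by a single change, (chloro in place of fluoro on an aromatic carbon), and in this assay compound 2 gives 610000 nM. The step from one to the other, a 1.0-fold higher number from compound 1 to compound 2 (0.01 log units; within the scatter), is small enough to count as no change at all on this read-out. Compound 3 `CCN(CC)CN1C(=O)/C(=N\NC(=S)NOC)c2cc(F)ccc21` has a different core; how the core of compound 3 differs from the core of compound 1 is not broken down here. In this assay compound 3 gives 490000 nM, and its numbers and those of compound 1 and compound 2 all lie within the usual scatter of one another, so no order among the three can be claimed.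

Compound 4 `CCN(CC)CN1C(=O)/C(=N\NC(=S)NOC)c2cc(Cl)ccc21` has not yet been measured. It is related to compound 3 by exactly the same change that relates compound 1 to compound 2, namely (chloro in place of fluoro on an aromatic carbon), made at the same place on the same kind of ring. Since that change produced a 1.0-fold higher number from compound 1 to compound 2 (0.01 log units; within the scatter), the step from compound 3 to compound 4 is expected to be similarly flat, a 1.0-fold higher number from compound 3 to compound 4 (0.01 log units; within the scatter). On that basis compound 4 is estimated to give 500000 nM in this assay, with a likely range from 300000 nM to 800000 nM.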

Compound 4, half-maximal cytotoxic concentration: 454000 nM
For compound 4 the middle estimate is 1.1-fold (0.04 log units) above the measured one; low and high end bracket the measured number.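

In this assay, putting chloro in place of fluoro on the aromatic carbon leaves compound 3 and compound 4 indistinguishable, with a 1.1-fold lower number from compound 3 to compound 4 (0.03 log units; within the scatter). Set beside the same swap on the other core, the step looks the same on both, so in this small series the flat result carries over from one core to the other: the same change on two cores in this assay, a 1.0-fold higher number (0.01 log units; within the scatter) from compound 1 to compound 2 and a 1.1-fold lower number (0.03 log units; within the scatter) from compound 3 to compound 4, 1.1-fold (0.04 log units) apart, within the scatter of two such steps

For the compounds shown here, this agreement rests on only two pairs of compounds, and since neither step rises above the scatter, it shows that the swap made no readable difference on these two cores, not that it would stay flat on other cores or in other tests.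

The compounds shown leave open what happens when the aromatic carbon bears something other than fluoro or chloro, such as bromo, a nitrile or an amine, and whether any such group would move the number beyond the scatter. They also leave open how each part of the difference between the two cores acts on its own, since the core of compound 1 and the core of compound 3 differ in more than one place.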